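A few compounds are considered here, and "the series" means these few. Any claim that something is new, unique, unknown or untested is made for them only; others in the source may bear on it.

Measured so far:
compound 1 `COc1ccc(Cn2cc(CNC(=O)c3cn(-c4ccccc4)nc3-c3ccccc3)nn2)cc1OC` — 10800 nM
compound 2 `COc1cc(Cn2cc(CNC(=O)c3cn(-c4ccccc4)nc3-c3ccccc3)nn2)cc(OC)c1OC` — > 100000 nM
compound 3 `COc1cc(Cn2cc(CNC(=O)c3cn(-c4ccccc4)nc3-c3ccc(F)cc3)nn2)cc(OC)c1` — 360 nM

All three values come from a functional assay on HeLa cells (Homo sapiens) for antiproliferative activity, read by sulforhodamine B assay, with a stated time of 48 h; a higher number here means a weaker inhibitor of growth, a lower number a stronger inhibitor of growth. In this assay compound 1 gives 10800 nM. Compound 2 reaches only a limit of the assay, > 100000 nM, and not a number. Compound 3 gives 360 nM, the lowest of the two numbers shown, with compound 1 standing at a higher number, beyond the scatter. How the core of compound 3 differs from that of compound 1 is not broken down here.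

Going by the values given here, the one change measured is methoxy in place of hydrogen on an aromatic carbon. It gives an at least 9.2-fold higher number from compound 1 to compound 2 (0.96 log units; beyond the scatter); the step can be given only as a bound because of the limit of > 100000 nM in this assay, at which 1 of the 3 values shown sits.

Compound 4 `COc1cc(Cn2cc(CNC(=O)c3cn(-c4ccccc4)nc3-c3ccc(F)cc3)nn2)cc(OC)c1OC` is not yet measured. It differs from compound 3 by methoxy in place of hydrogen on an aromatic carbon, the same kind of change as that from compound 1 to compound 2, though the surroundings differ: in compound 2 the new methoxy sits ortho to a methoxy group, meta to a large group and meta to a methoxy group, while in compound 4 it sits ortho to two methoxy groups and para to a large group.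

Resting on the step from compound 1 to compound 2 (an at least 9.2-fold higher number from compound 1 to compound 2 (0.96 log units; beyond the scatter)), the number for compound 4 is expected to rise relative to compound 3, the expected step being a 14-fold higher number from compound 3 to compound 4 (1.14 log units; beyond the scatter). The estimate for compound 4 in this assay is 5000 nM, between 1200 nM and 40000 nM.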

Compound 4, concentration for 50% growth inhibition: 2100 nM
Beside the measured number, compound 4's estimate is 2.4-fold (0.38 log units) above it; the measured number falls inside the stated range.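

In this assay, going from 3,5-dimethoxyphenyl to 3,4,5-trimethoxyphenyl gives a 5.8-fold higher number from compound 3 to compound 4 (0.77 log units; beyond the scatter), so methoxy in place of hydrogen on an aromatic carbon again goes with a weaker inhibitor of growth. Two pairs agree in direction, on two cores and with the new methoxy in different surroundings, but that does not show that the size of the step carries over, and two pairs set no rule for other cores: the same change on two cores in this assay, an at least 9.2-fold higher number (0.96 log units; beyond the scatter) from compound 1 to compound 2 and a 5.8-fold higher number (0.77 log units; beyond the scatter) from compound 3 to compound 4; the limit leaves it open whether they differ. With the 3,4,5-trimethoxyphenyl group held constant, fluoro in place of hydrogen on an aromatic carbon gives an at least 47-fold lower number from compound 2 to compound 4 (1.67 log units; beyond the scatter), so the core carrying the change does bear on the number reached, though this step is only a bound: the limit of > 100000 nM in this assay, at which 1 of the 4 values shown sits.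

Open, from the compounds shown here alone, is how far the methoxy step holds on cores with chloro or trifluoromethyl in place of the fluoro, since only the fluoro and the unsubstituted phenyl appear here. Also open, going by these compounds, is whether a hydroxy or an amine in the place para to a large group would go the same way as methoxy, and whether the fluoro step has a size that can be given as a number rather than a bound.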